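The source may hold more compounds than are shown below. What is called first, only, known or untested is meant among the compounds shown, and "the series" means these compounds.

In a functional assay on KYSE-70 cells for antiproliferative activity against KYSE-70 cell line (Homo sapiens), read by MTT assay, with a stated time of 72 h (on this read-out lower numbers stand for stronger inhibition and higher numbers for weaker inhibition), compound 1 `O=C(Nc1cccc(F)c1)c1cc(=O)[nH]c2cc(C3CC3)ccc12` gives > 20000 nM as a limit of the assay. Compound 2 `O=C(Nc1cccc(F)c1)c1cc(=O)[nH]c2cc(-c3cccnc3F)ccc12` also gives > 20000 nM as a limit and not a number. All that the measured step that the two limits leave unreadable from compound 1 to compound 2 offers is the limit of > 20000 nM in this assay, at which 2 of the 2 values shown sit, and no size. Compound 3 `C#Cc1ccc2c(C(=O)Nc3cccc(F)c3)cc(=O)[nH]c2c1` shows ethynyl in place of 2-fluoropyridin-3-yl on an aromatic carbon with ethynyl in place of 2-fluoropyridin-3-yl on an aromatic carbon. With no readable size to draw on, no shift in a known direction is expected in this assay and the expected result is a number no higher from compound 2 to compound 3 (the limit leaves the size open) with no clear trend. Compound 3 is estimated at 20000 nM with an expected range from 7000 nM to 40000 nM on this read-out.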

Compound 3, half-maximal inhibitory concentration: 9500 nM
Estimate against measurement, compound 3: 2.1-fold (0.32 log units) above; the range from low to high includes it.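

In this assay, ethynyl in place of 2-fluoropyridin-3-yl gives an at least 2.1-fold lower number from compound 2 to compound 3 (0.32 log units; beyond the scatter), and ethynyl in place of cyclopropyl gives an at least 2.1-fold lower number from compound 1 to compound 3 (0.32 log units; beyond the scatter). Compound 3 is thus the first of the three to give a readable number, showing that a change at this position can bring the series off the limit. Compound 1 and compound 2, which carry ring groups here, both stay at a limit, so each step has a minimum and no exact size: the limit of > 20000 nM in this assay, at which 2 of the 3 values shown sit.

The compounds shown leave open whether an ethyl group, a nitrile or a longer alkyne chain at this position would give a number lower or higher than that of compound 3.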